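The source may hold more compounds than are shown below. What is called first, only, known or untested is meant among the compounds shown, and "the series" means these compounds.

Compound 1 `O=C(N/N=C/c1cccnc1)c1cc2ccccc2oc1=O`: 15300 nM
Compound 2 `O=C(N/N=C/c1cccnc1)c1cc2cc([N+](=O)[O-])ccc2oc1=O`: 11800 nM

In a functional assay on PANC-1 cells (Homo sapiens) for antiproliferative activity, read by fluorescence and resazurin assay, with a stated time of 48 h (a higher number here means a weaker inhibitor, a lower number a stronger inhibitor), compound 2 gives 11800 nM, and this cannot be told apart from the other measured compound, since compound 1 gives 15300 nM. Compound 3 `O=C(N/N=C/c1cccnc1)c1cc2cc(Br)ccc2oc1=O` keeps the same core and side chain but changes one group. The change is bromo in place of nitro on an aromatic carbon, or in words, bromo in place of nitro on an aromatic carbon. Among the compounds with values here, only one measured step bears on this carbon: a 1.3-fold lower number from compound 1 to compound 2 (0.11 log units; within the scatter). Placing nitro there in place of hydrogen therefore moved the number by no more than ordinary repeat measurements do. Within the data shown here, no measured compound carries bromo, so the data give no direct guide to that group. No real shift in this assay is expected in either direction. The expected change is a 1.1-fold lower number from compound 2 to compound 3 (0.03 log units; within the scatter). For compound 3 the estimated value is 11000 nM, with an expected range of 5000 nM to 24000 nM.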

Compound 3, half-maximal inhibitory concentration: 8350 nM
Compound 3: the middle estimate sits 1.3-fold (0.12 log units) above what was measured; measured number inside the range.
By their numbers in this assay, from the lowest: compounds 3, 2 and 1 (each within the scatter of the next).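

In this assay, putting bromo in place of nitro on this aromatic carbon gives a 1.4-fold lower number from compound 2 to compound 3 (0.15 log units; within the scatter), and bromo in place of hydrogen gives a 1.8-fold lower number from compound 1 to compound 3 (0.26 log units; within the scatter). Hydrogen, nitro and bromo have therefore all been tried at this one carbon, and no pair among them can be told apart in this assay. Even losing the hydrogen-bond acceptors of nitro, in the exchange for bromo, leaves the number within the scatter, and no other measurement is available to explain these readings. On these data alone, whether an amine or a carboxylic acid on this carbon would produce a step beyond the scatter remains open. Also unknown is how changes elsewhere on the shared core or in the side chain would affect the number.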